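Methoxy for fluoro on the benzyl ring: what to expect

This account rests on a few compounds, and the source may have more. Where it says the series, first, only, none or still open, it means among the compounds named here.

Going by the values given here, in a functional assay on MCF7 cells (Homo sapiens) for inhibition, read by sulforhodamine B assay, with a stated time of 48 h (on this read-out higher numbers stand for weaker inhibition of growth and lower numbers for stronger inhibition of growth), compound 2 `Nc1cc(N)c2nc(-c3ccccc3)c(NCc3ccc(F)cc3)nc2c1` gives 3020 nM, the lower of the two numbers so far; compound 1 `COc1ccc(CNc2nc3cc(N)cc(N)c3nc2-c2ccccc2)cc1OC` gives 25700 nM. Among the compounds with values here, the one measured step, an 8.5-fold lower number from compound 1 to compound 2 (0.93 log units; beyond the scatter), is the only guide. Compound 3 `COc1ccc(CNc2nc3cc(N)cc(N)c3nc2-c2ccccc2)cc1` differs from compound 2 by methoxy in place of fluoro on an aromatic carbon. That step also trims the difference between compound 1 and compound 2, so compound 3 is expected to sit between them, with a modest rise a 2.6-fold higher number from compound 2 to compound 3 (0.42 log units; beyond the scatter). Compound 3 is therefore estimated at 8000 nM, within 3000 nM to 24000 nM.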

Compound 3, concentration for 50% growth inhibition: 13200 nM
Compound 3: middle estimate off by 1.7-fold (0.22 log units), on the low side, and the stated range covers the measured number.
By their numbers in this assay, from the lowest: compound 2; then compounds 3 and 1 (each within the scatter of the next).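

In this assay, changing only the group on the aromatic carbon para to a large group, from fluoro to methoxy, already has a clear effect (with a 4.4-fold higher number from compound 2 to compound 3 (0.64 log units; beyond the scatter)). Going by these compounds alone, the further methoxy of compound 1 adds nothing readable (with a 1.9-fold lower number from compound 1 to compound 3 (0.29 log units; within the scatter)), so the two methoxy compounds cannot be ordered, and most of the gap to compound 2 appears with the single change from fluoro to methoxy. Nothing available here explains this difference.

The compounds shown leave open how a chloro group, a hydroxyl group or an amine at this place would compare with fluoro and methoxy. They also leave open whether a longer chain between the ring and the nitrogen would change the picture.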